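Crown ether esters: growth inhibition in HeLa cells

The source may report more compounds than this note shows. Statements on the series, on what has been measured and on what is new or still open speak of the compounds shown alone.

Measured compounds:
compound 1 `CC/C=C/CC(=O)OCC1COCCOCCOCCOCCOCCO1` — > 100000 nM
compound 2 `O=C(OCC1COCCOCCOCCOCCOCCO1)c1cccnc1` — > 100000 nM

In a functional assay on HeLa cells (Homo sapiens) for inhibition, read by sulforhodamine B assay, with a stated time of 48 h (a lower number here means a stronger inhibitor of growth, a higher number a weaker inhibitor of growth), compound 1 gives > 100000 nM, which is a limit of the assay and not a number. Compound 2 gives > 100000 nM in this assay, again a limit. Within the data shown here, compound 1 thus stands at the limit, and the one further value shown sits at that same limit (the limit of > 100000 nM in this assay, at which 2 of the 2 values shown sit). Among the measured compounds shown here, the single measured step, a step that the two limits leave unreadable from compound 1 to compound 2, exchanges pent-2-en-1-yl for pyridin-3-yl on a carbonyl carbon; it has no readable size, both of its ends being limits.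

Compound 3 `O=C(CCCc1cc2ccccc2[nH]1)OCC1COCCOCCOCCOCCOCCO1` is to be measured in this assay. Its change from compound 1 is 2-(1H-indol-2-yl)ethyl in place of but-1-en-1-yl on a saturated chain carbon bound to a carbonyl carbon. For the measured compounds named here, only the unreadable step bears on this change, and no measured compound shows growth inhibition within the assay range, so there is no measured basis for a shift in either direction. The step expected from this change is a number no higher from compound 1 to compound 3 (the limit leaves the size open), with a limit again the likeliest outcome. The estimate for compound 3 is 100000 nM, with a range from 30000 nM to 400000 nM.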

Compound 3, concentration for 50% growth inhibition: > 100000 nM
Compound 3: only a limit was reported (the forecaster's own chance of this, stated with the estimate: 75%); the middle value lies on the limit itself.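

In this assay compound 3 gives > 100000 nM, a limit of the assay and not a number. No step between compound 1 and compound 3 can be read, and the series stays at one limit: the limit of > 100000 nM in this assay, at which 3 of the 3 values shown sit.

The compounds shown leave open whether any group on the shared core brings growth inhibition within the assay range, and how these groups rank.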